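The source may report more compounds than this note shows. Statements on the series, on what has been measured and on what is new or still open speak of the compounds shown alone.

Of the compounds shown here, two have numbers so far. In a functional assay on the whole organism with Mus musculus as the target (on this read-out lower numbers stand for an effect already at smaller amounts and higher numbers for an effect only at larger amounts of compound), compound 1 (`CNC(=O)[C@@H](NCc1ccc(OCc2ccccc2)cc1)C(C)C`) gives 55.4 mg/kg. Compound 2 (`C[C@@H](NCc1ccc(OCCc2ccccc2)cc1)C(N)=O`) gives 24.9 mg/kg, the lower of the two numbers, and its gap to compound 1 lies beyond the scatter. Going by the values given here, no measured pair differs in one place only, so the series offers no direct precedent for the next change.

Compound 3 (`C[C@@H](NCc1ccc(OCc2ccc(F)cc2)cc1)C(N)=O`) carries 4-fluorophenyl in place of benzyl on a saturated chain carbon bound to an oxygen on an aromatic ring, relative to compound 2: 4-fluorophenyl in place of benzyl on a saturated chain carbon bound to an oxygen on an aromatic ring. Among the compounds with values here, with no measured step to draw on, the expectation is loose. A modest step of a 1.8-fold lower number from compound 2 to compound 3 (0.25 log units; within the scatter) toward a lower number is expected, of a size near the scatter. For compound 3 the estimated dose in this assay is 14 mg/kg, with an expected range of 6 mg/kg to 35 mg/kg.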

Compound 3, dose for half-maximal effect: 132 mg/kg
Estimate against measurement, compound 3: 9.4-fold (0.97 log units) below, and the stated range ends below it.
By their numbers in this assay, from the lowest: compound 2; then compound 1; then compound 3.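

Notes on this position: on a saturated chain carbon bound to an oxygen on an aromatic ring, 4-fluorophenyl in place of benzyl gives a 5.3-fold higher number from compound 2 to compound 3 (0.72 log units; beyond the scatter) in this assay and is the first single-place step in the series. The position is therefore not indifferent to the group it carries. The two groups match in heavy atoms, ring type, hydrogen-bond donors and acceptors and charge, so these counts do not account for the step in this pair.

Still open, going by these compounds, is whether the step follows the fluorine or the change in chain, and plain phenyl or 4-fluorobenzyl at this place would separate the two. Nothing available on these compounds explains the size or direction of the step.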